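The source may report more compounds than this note shows. Statements on the series, on what has been measured and on what is new or still open speak of the compounds shown alone.

The measured compounds and their values:

compound 1, `COC(=O)c1c(-c2ccc(OCc3ccccc3)cc2)oc2ccccc2c1=O`, > 25 ug/mL
compound 2, `COC(=O)c1c(-c2ccc(OCc3ccccc3)cc2)oc2ccc(OC)cc2c1=O`, > 25 ug/mL
compound 3, `O=C(O)c1c(-c2ccc([N+](=O)[O-])cc2)oc2ccccc2c1=O`, > 25 ug/mL

The three compounds were tested in a functional assay on MCF7 cells (Homo sapiens) for cytotoxicity, read by MTT assay, with a stated time of 6 days; a higher number here means that more compound is needed for the effect, a lower number that less compound is needed. Compound 1 reaches only the limit of the assay there, > 25 ug/mL, and no number is known for it. Compound 2 likewise gives only the limit, > 25 ug/mL. Compound 3 also sits at the limit, > 25 ug/mL. Because (the limit of > 25 ug/mL in this assay, at which 3 of the 3 values shown sit), none of the three can be placed at a definite value.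

Compound 2 differs from compound 1 by one change, (methoxy in place of hydrogen on an aromatic carbon). The size of this step, a step that the two limits leave unreadable from compound 1 to compound 2, cannot be read, since both ends are limits. Compound 3 has a different core from compound 1; the difference between the two cores is not broken down here.

The unmeasured compound 4, `COc1ccc2c(=O)c(C(=O)O)c(-c3ccc([N+](=O)[O-])cc3)oc2c1`, stands to compound 3 as compound 2 stands to compound 1: methoxy in place of hydrogen on an aromatic carbon. For compound 4 in this assay the expected step is a step that the limit leaves unreadable from compound 3 to compound 4, and this rests on compound 3 giving > 25 ug/mL together with compound 1 and compound 2 both sitting at the same limit on either side of the same change. Compound 4 is therefore estimated at 35 ug/mL, with a likely range from 15 ug/mL to 120 ug/mL, and most probably it too will be reported only as a limit.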

Compound 4, concentration for half-maximal effect: > 25 ug/mL
Compound 4: no number, only a limit (the forecaster's own chance of this, stated with the estimate: 85%); the middle value is on the limit's open side.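

In this assay compound 4 gives > 25 ug/mL, which is a limit and not a number. No new step can be read for methoxy in place of hydrogen between compound 3 and compound 4, because both ends are limits: the limit of > 25 ug/mL in this assay, at which 4 of the 4 values shown sit.

The compounds shown leave open what definite value any of them would have in this assay, and whether the methoxy change alters it.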